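The source may report more compounds than this note shows. Statements on the series, on what has been measured and on what is new or still open speak of the compounds shown alone.

Compound 1, `CC(=O)O[C@@H]1C[C@@H](OC(C)=O)C(C)(C)[C@H](O)[C@H]2O[C@@]3(C[C@H](C)[C@H](OC(=O)c4ccccc4)[C@@H]3/C=C/1C)[C@@H](OC(C)=O)[C@H]2C`: in a functional assay on HeLa cells (Homo sapiens) for cytotoxicity, read by MTT assay (on this read-out higher numbers stand for weaker inhibition and lower numbers for stronger inhibition), compound 1 gives > 10000 nM, which is a limit of the assay and not a number.
Compound 2, `CC(=O)O[C@@H]1[C@H]2O[C@@]3(C[C@H](C)[C@H](OC(=O)c4ccccc4)[C@@H]3/C=C(\C)[C@H](OC(C)=O)C[C@@H](OC(C)=O)C1(C)C)[C@@H](OC(C)=O)[C@H]2C`: in this assay compound 2 gives > 10000 nM, again a limit of the assay.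
Compound 3, `CC(=O)O[C@@H]1C[C@@H](O)C(C)(C)/C=C/[C@H](C)[C@H](OC(C)=O)[C@@]2(O)C[C@H](C)[C@H](OC(=O)c3ccccc3)[C@@H]2/C=C/1C`: in this assay compound 3 gives > 10000 nM, also a limit of the assay.

Compound 3 therefore stands where every measured compound stands: at the limit, with no number to place it against the others, because of the limit of > 10000 nM in this assay, at which 3 of the 3 values shown sit.

The next compound is compound 4, `CC(=O)O[C@@H]1C[C@@H](OC(C)=O)C(C)(C)/C=C/[C@H](C)[C@H](OC(C)=O)[C@@]2(O)C[C@H](C)[C@H](OC(=O)c3ccccc3)[C@@H]2/C=C/1C`. It differs from compound 3 in one place: acetyl in place of hydrogen on an oxygen on a saturated carbon. The same kind of change has been measured once, a step that the two limits leave unreadable from compound 1 to compound 2, but both ends of that step sit at the limit, so its size cannot be read. Within the data shown here, there is thus no measured step that tells how large an effect to expect in this assay, or in which direction.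

With nothing to lean on, the expectation for compound 4 rests on compound 3 staying where it is: compound 4 is estimated at 15000 nM, within 5000 nM to 50000 nM, meaning an expected step that the limit leaves unreadable from compound 3 to compound 4, most likely reported again only as a limit.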

Compound 4, half-maximal inhibitory concentration: 3100 nM
Compound 4: middle estimate off by 4.8-fold (0.68 log units), on the high side, and the stated range ends above it.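

Acetoxy in place of hydroxy on this oxygen on a saturated carbon is the first change here to give a readable effect in this assay, with an at least 3.2-fold lower number from compound 3 to compound 4 (0.50 log units; beyond the scatter). Going by these compounds, compound 3 gives > 10000 nM, which is a limit of the assay and not a number, so the true size of the step remains unknown. The same kind of change from compound 1 to compound 2 cannot be read, which makes this pair the only evidence that adding an acetyl can lower the number, and compound 4 is the only compound with a measured number rather than a limit: the limit of > 10000 nM in this assay, at which 3 of the 4 values shown sit.

On these data alone, what remains open is whether the effect belongs to the acetyl group itself or would also appear with a longer chain on the ester, such as butanoyl, or with a methyl ether or an amine at the same place. Among these compounds, it is also open whether acetyl on other oxygens of the shared core could lower the number in the same way, since the only other such pair gives no readable size.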